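The source may report more compounds than this note shows. Statements on the series, on what has been measured and on what is new or still open speak of the compounds shown alone.

Measured in a functional assay on HCT-116 cells (Homo sapiens) for antiproliferative activity, read by sulforhodamine B assay, with a stated time of 48 h; on this read-out lower numbers stand for stronger inhibition and higher numbers for weaker inhibition:
compound 1 `O=C(NCCCNc1cc(-c2cn(-c3ccccc3)nc2-c2cccc(O)c2)ccn1)Nc1ccc(F)cc1` gives 1620 nM
compound 2 `O=C(NCCCNc1cc(-c2cn(-c3ccccc3)nc2-c2cccc(O)c2)ccn1)Nc1cccc(C(F)(F)F)c1` gives 1970 nM

Going by the values given here, only these two compounds have numbers so far, and compound 1 stands level with compound 2, its one neighbour. Compound 3 `COc1cccc(-c2nn(-c3ccccc3)cc2-c2ccnc(NCCCNC(=O)Nc3ccc(F)cc3)c2)c1` differs from compound 1 by methyl in place of hydrogen on an oxygen on an aromatic ring and so reads as hydroxy to methoxy, or 3-hydroxyphenyl to 3-methoxyphenyl. Among the compounds with values here, no measured step touches this group, so the data give no direct guide. Within the data shown here, the single step available concerns another place, with 3-(trifluoromethyl)phenyl in place of 4-fluorophenyl on an amide-type nitrogen. Compound 2 bears on the question only loosely, showing that this one change in the series gave a 1.2-fold higher number from compound 1 to compound 2 (0.08 log units; within the scatter) and stayed within the scatter. On that thin basis, a small step is expected in this assay and little or nothing clearly beyond the scatter, with a slight lean toward a higher number and the direction uncertain. The expected step is a 1.5-fold higher number from compound 1 to compound 3 (0.17 log units; within the scatter) and remains only an estimate. For compound 3 the estimated value is 2400 nM with an expected range from 1000 nM to 6500 nM in this assay.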

Compound 3, half-maximal inhibitory concentration: 5700 nM
The estimate for compound 3 lay 2.4-fold (0.38 log units) below the measured number; the measured number falls inside the stated range.
By their numbers in this assay, from the lowest: compounds 1 and 2 (each within the scatter of the next); then compound 3.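

In this assay, going by these compounds alone, going from 3-hydroxyphenyl to 3-methoxyphenyl gives a 3.5-fold higher number from compound 1 to compound 3 (0.55 log units; beyond the scatter), the first step in this small series to lie beyond the scatter. It shows that a single methyl on this oxygen on an aromatic ring, just one added heavy atom, is enough to move the number in the weaker direction, whereas the change on the amide-type nitrogen gave only a 1.2-fold higher number from compound 1 to compound 2 (0.08 log units; within the scatter). Nothing at hand explains why the number rises with this change.

The compounds shown do not tell how an ethyl on the same oxygen, or an amine or a fluorine in place of the hydroxy, would read, so it remains open whether the free hydroxy itself matters or only the methyl placed on it. They also leave open whether the methoxy step would keep its size alongside the 3-(trifluoromethyl)phenyl of compound 2, as this single pair cannot show how the two places act together.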